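From compound 1 to compound 4: a piperazine exchange

This account rests on a few compounds, and the source may have more. Where it says the series, first, only, none or still open, it means among the compounds named here.

Compound 1 `CCCCN1CCN(CCCCn2c3c(c4ccccc42)C(=O)c2c[n+]([O-])c4ccccc4c2C3=O)CC1` gives 6100 nM
Compound 2 `CC1(C)OC[C@@H](Cn2cc(Cn3c4c(c5ccccc53)C(=O)c3c[n+]([O-])c5ccccc5c3C4=O)nn2)O1` gives > 1000 nM (a limit of the assay)
Compound 3 `O=C1c2c[n+]([O-])c3ccccc3c2C(=O)c2c1c1ccccc1n2Cc1cn([C@@H]2O[C@H](CO)[C@@H](O)[C@H](O)[C@H]2O)nn1` gives 880 nM

In a functional assay on SH-SY5Y cells (Homo sapiens) for cytotoxicity, read by MTT assay, with a stated time of 72 h (a lower number here means a stronger inhibitor, a higher number a weaker inhibitor), compound 1 stands at 6100 nM as the higher of the two actual numbers. Compound 3 lies lower at 880 nM with a gap beyond the scatter. For compound 2 there is only a limit (> 1000 nM) and no number.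

Compound 4 `CN1CCN(CCCCCn2c3c(c4ccccc42)C(=O)c2c[n+]([O-])c4ccccc4c2C3=O)CC1` has not yet been measured, and it differs from compound 1 in one place ((4-methylpiperazin-1-yl)methyl in place of 4-butylpiperazin-1-yl on a saturated chain carbon, four bonds along the chain from an aromatic nitrogen). Cut one bond further out, the same difference reads 2-(4-butylpiperazin-1-yl)ethyl to 3-(4-methylpiperazin-1-yl)propyl.

The only measured step among these compounds is an at least 1.1-fold lower number from compound 2 to compound 3 (0.05 log units; that floor lies within the scatter) and it exchanges other groups on an aromatic nitrogen, so it gives no direct guide to this change. The expectation therefore rests on compound 1 at 6100 nM as its sole anchor, with a wide range. The step expected in this assay is a 1.5-fold lower number from compound 1 to compound 4 (0.18 log units; within the scatter) and no step beyond the scatter is expected in either direction. Compound 4 is expected at 4000 nM with a range from 1300 nM to 12000 nM in this estimate.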

Compound 4, half-maximal inhibitory concentration: 830 nM
Compound 4: the middle estimate sits 4.8-fold (0.68 log units) above what was measured, outside the stated range (below it).
By their numbers in this assay, from the lowest: compounds 4 and 3 (each within the scatter of the next); then compound 1.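

In this assay, the end of the chain on the aromatic nitrogen proves to matter: (4-methylpiperazin-1-yl)methyl in place of 4-butylpiperazin-1-yl, on a saturated chain carbon, four bonds along the chain from an aromatic nitrogen, gives a 7.3-fold lower number from compound 1 to compound 4 (0.87 log units; beyond the scatter). Among the compounds shown here, this is the first measured step at this position to pass the scatter, since the earlier step between two other groups on an aromatic nitrogen had only a floor that lay within it. Nothing shown here gives a cause for this step.

The same difference also reads as 2-(4-butylpiperazin-1-yl)ethyl to 3-(4-methylpiperazin-1-yl)propyl, so the step joins a change in the group on the piperazine with a change in the chain that carries it, and the share of each stays unresolved. Still open, from the compounds shown here alone, is how this assay would respond to a compound that changes only one of these, such as a butyl-bearing piperazine on the longer chain or a methyl-bearing one on the shorter chain, and to a morpholine at the chain end.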